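The source may hold more compounds than are shown below. What is called first, only, known or untested is meant among the compounds shown, and "the series" means these compounds.

Measured compounds:
compound 1 `C#CCSc1nc(Nc2cccc(Cl)c2)c(C#N)c(-c2ccccc2)n1`, 10500 nM in a functional assay on B16-F10 cells (Mus musculus) for inhibition, read by MTT assay, with a stated time of 72 h; a higher number here means a weaker inhibitor, a lower number a stronger inhibitor
compound 2 `N#Cc1c(Nc2cccc(Cl)c2)nc(SCc2cn(Cc3ccccc3Cl)nn2)nc1-c1ccccc1`, 3590 nM

In this assay compound 2 gives 3590 nM, the lower of the two numbers, and compound 1 gives 10500 nM, a gap beyond the usual scatter. Compound 3 `N#Cc1c(Nc2ccccc2)nc(SCc2cn(Cc3ccccc3Cl)nn2)nc1-c1ccccc1` differs from compound 2 by hydrogen in place of chloro on an aromatic carbon. Within the data shown here, no measured pair shows this change, so its weight cannot be read from the series. The step in this assay is expected to be small, toward a somewhat higher number, as a 1.5-fold higher number from compound 2 to compound 3 (0.19 log units; within the scatter). Compound 3 is estimated at 5500 nM, within a range of 2000 nM to 14000 nM.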

Compound 3, half-maximal inhibitory concentration: 28300 nM
Compound 3: the middle estimate sits 5.1-fold (0.71 log units) below what was measured; measured number above the stated range.
By their numbers in this assay, from the lowest: compound 2; then compound 1; then compound 3.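

In this assay, hydrogen in place of chloro on an aromatic carbon gives a 7.9-fold higher number from compound 2 to compound 3 (0.90 log units; beyond the scatter). Among these compounds, this is the first direct reading of the position: the 3-chlorophenyl group and the plain phenyl group are not interchangeable here, and the loss of one chlorine atom alone carries a step beyond the scatter. Nothing at hand bears on the reason for this step.

Still open, as far as these compounds go, is whether chloro is special at this carbon or whether fluoro, methyl or methoxy would serve equally. A single pair also leaves open whether the step holds with other groups on the sulfur.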